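Thiourea aryl swap on a shared thiophene-carboxamide core

The source may report more compounds than this note shows. Statements on the series, on what has been measured and on what is new or still open speak of the compounds shown alone.

Measured compounds:
compound 1 `N#Cc1ccccc1CN1CCc2c(sc(NC(=O)c3ccccc3Cl)c2C(N)=O)C1`: 9500 nM
compound 2 `NC(=O)c1c(NC(=O)c2ccccc2Cl)sc2c1CCN(Cc1c(Cl)cccc1Cl)C2`: 4740 nM
compound 3 `Cc1ccccc1NC(=S)N1CCc2c(sc(NC(=O)c3ccccc3Cl)c2C(N)=O)C1`: 11700 nM

In a functional assay on MKN-74 cells (Homo sapiens) for antiproliferative activity, with a stated time of 24 h (a lower number here means a stronger inhibitor, a higher number a weaker inhibitor), compound 3 gives the highest of the three numbers; compound 1 sits within the scatter of it, while compound 2 lies lower by a 2.5-fold higher number from compound 2 to compound 3 (0.39 log units; beyond the scatter). Compound 4 `COc1ccc(NC(=S)N2CCc3c(sc(NC(=O)c4ccccc4Cl)c3C(N)=O)C2)cc1` differs from compound 3 by 4-methoxyphenyl in place of 2-methylphenyl on an amide-type nitrogen. Going by the values given here, no measured step alters this aryl group: the steps of a 2.0-fold lower number from compound 1 to compound 2 (0.30 log units; within the scatter) and a 1.2-fold higher number from compound 1 to compound 3 (0.09 log units; within the scatter) change the whole substituent on the ring amine nitrogen instead, and all three steps are small. Compound 4 is therefore expected to show no step beyond the scatter, a 1.1-fold lower number from compound 3 to compound 4 (0.03 log units; within the scatter), with an estimated value of 11000 nM in a range from 4000 nM to 30000 nM.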

Compound 4, half-maximal inhibitory concentration: 19600 nM
For compound 4 the middle estimate is 1.8-fold (0.25 log units) below the measured one; the range from low to high includes it.
By their numbers in this assay, from the lowest: compounds 2, 1, 3 and 4 (each within the scatter of the next, the first and the last beyond it).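

Replacing 2-methylphenyl with 4-methoxyphenyl on the amide-type nitrogen gives a 1.7-fold higher number from compound 3 to compound 4 (0.22 log units; within the scatter) in this assay and so leaves the number within the scatter. With this aryl group in place, changing the whole substituent on the ring amine nitrogen now separates compounds: a 2.1-fold higher number from compound 1 to compound 4 (0.31 log units; beyond the scatter) and a 4.1-fold higher number from compound 2 to compound 4 (0.62 log units; beyond the scatter) are both modest steps beyond the scatter. No measured evidence accounts for these steps.

As far as these compounds go, whether an amine or a carboxylic acid on this phenyl ring would move the number stays open. So does the outcome of a longer chain on the amide-type nitrogen in place of the aryl group.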